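Trifluorophenyl isomers in the Jurkat series: compound 3 to compound 4

The source may report more compounds than this note shows. Statements on the series, on what has been measured and on what is new or still open speak of the compounds shown alone.

In a functional assay on Jurkat cells (Homo sapiens) (on this read-out higher numbers stand for weaker inhibition and lower numbers for stronger inhibition), compound 3 `CC(C)[C@H](NC(=O)COc1cccc2ccccc12)C(=O)N[C@@H](CC(=O)O)C(=O)COc1ccc(F)c(F)c1F` gives 35800 nM, the higher of the two true numbers in the series. The other number belongs to compound 2 `CC(C)[C@H](NC(=O)COc1cccc2ccccc12)C(=O)N[C@@H](CC(=O)O)C(=O)COc1c(F)ccc(F)c1F`, at 1200 nM. Compound 1 `CC(C)[C@H](NC(=O)COc1cccc2ccccc12)C(=O)N[C@@H](CC(=O)O)C(=O)COc1cccc2ccccc12` returns only a limit, > 100000 nM.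

Compound 4 `CC(C)[C@H](NC(=O)COc1cccc2ccccc12)C(=O)N[C@@H](CC(=O)O)C(=O)COc1cc(F)cc(F)c1F` is an isomer of compound 3: 2,3,5-trifluorophenyl in place of 2,3,4-trifluorophenyl on an oxygen on a saturated carbon. Only the trifluorophenyl isomers bear closely on this change. Among the compounds with values here, the one measured exchange of this kind is large, a 30-fold higher number from compound 2 to compound 3 (1.47 log units; beyond the scatter), so an isomer swap alone can move this read-out well beyond the scatter. Within the data shown here, the naphthalen-1-yl exchanges, an at least 83-fold lower number from compound 1 to compound 2 (1.92 log units; beyond the scatter) and an at least 2.7-fold lower number from compound 1 to compound 3 (0.44 log units; beyond the scatter), show only that both measured trifluorophenyl compounds improve on compound 1. With a single isomer pair as a guide, neither size nor direction is firmly set, so a modest gain is expected, with a wide margin. The expected step is a 3.0-fold lower number from compound 3 to compound 4 (0.47 log units; beyond the scatter). For compound 4 the estimate in this assay is 12000 nM, with an expected range of 2000 nM to 60000 nM.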

Compound 4, half-maximal inhibitory concentration: 30000 nM
The estimate for compound 4 lay 2.5-fold (0.40 log units) below the measured number; the measured number falls inside the stated range.
By their numbers in this assay, from the lowest: compound 2; then compounds 4 and 3 (each within the scatter of the next). At a limit, above all of these: compound 1.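

In this assay, the step of a 1.2-fold lower number from compound 3 to compound 4 (0.08 log units; within the scatter) lies within the scatter, so the 2,3,4-trifluorophenyl and 2,3,5-trifluorophenyl isomers on this oxygen cannot be told apart, and an isomer swap at this position need not move the read-out. The step of a 25-fold higher number from compound 2 to compound 4 (1.40 log units; beyond the scatter) is large, which leaves 2,3,6-trifluorophenyl apart from both other isomers rather than from one alone. Within the data shown here, the remaining step, an at least 3.3-fold lower number from compound 1 to compound 4 (0.52 log units; beyond the scatter), has a limit at one end, so it gives only a minimum size, and compound 1 stays the one compound without a true number: the limit of > 100000 nM in this assay, at which 1 of the 4 values shown sits.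

Going by these compounds, whether the advantage of 2,3,6-trifluorophenyl needs all of its fluorines stays open. Plain phenyl and pentafluorophenyl on the same oxygen would test how far this isomer effect extends.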